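From 4-chlorophenyl to 2,4-difluorophenyl on the ethenyl chain

A few compounds are considered here, and "the series" means these few. Any claim that something is new, unique, unknown or untested is made for them only; others in the source may bear on it.

- compound 1 `N#Cc1ccc(/C=C/S(=O)(=O)Cc2ccc(Nc3ncnc4ccccc34)cc2)cc1`: > 100000 nM (a limit)
- compound 2 `O=S(=O)(/C=C/c1ccc(Br)cc1)Cc1ccc(Nc2ncnc3ccccc23)cc1`: > 100000 nM (a limit)
- compound 3 `O=S(=O)(/C=C/c1ccc(Cl)cc1)Cc1ccc(Nc2ncnc3ccccc23)cc1`: 49000 nM

Going by the values given here, in a functional assay on U-251 cells (Homo sapiens) (a lower number here means a stronger inhibitor of growth, a higher number a weaker inhibitor of growth), compound 3 gives 49000 nM, the only actual number in the set. The other two compounds stop at the limit of > 100000 nM in this assay, at which 2 of the 3 values shown sit.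

Compound 4 `O=S(=O)(/C=C/c1ccc(F)cc1F)Cc1ccc(Nc2ncnc3ccccc23)cc1` differs from compound 3 in one place: 2,4-difluorophenyl in place of 4-chlorophenyl on a double-bonded chain carbon bound to a double-bonded chain carbon. In words, 2,4-difluorophenyl stands in place of 4-chlorophenyl on a double-bonded chain carbon bound to a double-bonded chain carbon.

The measured steps each swap one group on an aromatic carbon. They are an at least 2.0-fold lower number from compound 1 to compound 3 (0.30 log units; that floor lies within the scatter) and an at least 2.0-fold lower number from compound 2 to compound 3 (0.30 log units; that floor lies within the scatter), along with a step that the two limits leave unreadable from compound 1 to compound 2. None of them involves fluorine, so they give only a loose guide. Among the compounds with values here, compound 2 shows through an at least 2.0-fold lower number from compound 2 to compound 3 (0.30 log units; that floor lies within the scatter) that such a swap can carry the number to the limit, so a small move towards a higher number is expected, with no step clearly beyond the scatter.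

The expected step is a 1.4-fold higher number from compound 3 to compound 4 (0.15 log units; within the scatter). For compound 4 the estimated value is 70000 nM, with an expected range from 30000 nM to 160000 nM.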

Compound 4, concentration for 50% growth inhibition: > 100000 nM
Compound 4: a limit, no number; the forecaster's own chance of this, stated with the estimate: 45%; at least 1.4-fold (0.15 log units) between middle value and limit.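

In this assay compound 4 gives > 100000 nM as a limit and not a number. Replacing 4-chlorophenyl with 2,4-difluorophenyl gives an at least 2.0-fold higher number from compound 3 to compound 4 (0.30 log units; that floor lies within the scatter) and so shows that a ring with two fluorines on a double-bonded chain carbon bound to a double-bonded chain carbon brings no gain over compound 3, although the true size of the step stays hidden behind the limit. Going by these compounds alone, the steps from compound 1 and from compound 2 to compound 4 cannot be read, and compound 3 remains the only compound with a number, the others all sitting at one ceiling: the limit of > 100000 nM in this assay, at which 3 of the 4 values shown sit.

The compounds shown leave open whether any group in this place can give a number clearly lower than that of compound 3. A phenyl ring carrying an amine or a methoxy group in place of 4-chlorophenyl remains an open case.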